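From benzyl to cyanomethyl on the sulfur chain

The source may hold more compounds than are shown below. What is called first, only, known or untested is meant among the compounds shown, and "the series" means these compounds.

In a functional assay (Homo sapiens) for inhibition (a lower number here means a stronger inhibitor, a higher number a weaker inhibitor), compound 3 (`Fc1ccc(-c2[nH]c(SCc3ccccc3)nc2-c2ccncc2)cc1`) gives 300 nM as its value. Compound 1 (`CSc1cccc(CSc2nc(-c3ccc(F)cc3)c(-c3ccncc3)[nH]2)c1`) gives 550 nM and compound 2 (`C[S+]([O-])c1ccc(CCSc2nc(-c3ccc(F)cc3)c(-c3ccncc3)[nH]2)cc1`) gives 500 nM so all three lie within the scatter of one another.

Compound 4 (`N#CCSc1nc(-c2ccncc2)c(-c2ccc(F)cc2)[nH]1`) has not yet been measured. Its difference from compound 3 is cyano in place of phenyl on a saturated chain carbon bound to a sulfur and amounts to cyano in place of phenyl on a saturated chain carbon bound to a sulfur.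

Within the data shown here, the only measured step at that place is a 1.1-fold lower number from compound 1 to compound 2 (0.04 log units; within the scatter) and it offers limited guidance. Among the measured compounds shown here, both groups in that step keep a six-membered aromatic ring of carbon only, as does compound 3, so losing that ring has no measured precedent. With compound 3 at 300 nM as the starting point, a modest step toward a higher number in this assay is expected, although a result within the scatter would not be surprising. The expected change is a 2.3-fold higher number from compound 3 to compound 4 (0.37 log units; beyond the scatter) on this estimate. Compound 4 is estimated at 700 nM with an expected range of 200 nM to 2500 nM for now.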

Compound 4, half-maximal inhibitory concentration: < 100 nM
Compound 4: no number, only a limit (the forecaster's own chance of this, stated with the estimate: 5%); at least 7.0-fold (0.84 log units) between middle value and limit.
By their numbers in this assay, from the lowest: compounds 3, 2 and 1 (each within the scatter of the next). At a limit, below all of these: compound 4.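

In this assay, a six-membered aromatic ring of carbon only is not required on the sulfur chain: the step with cyano in place of phenyl reads an at least 3.0-fold lower number from compound 3 to compound 4 (0.47 log units; beyond the scatter). Compound 4 gives < 100 nM, which is a limit of the assay and not a number. Compounds 1, 2 and 3 all keep that ring and lie within the scatter of one another, so this is the first change at this place shown to go beyond the scatter, and it runs towards a lower number.

The step therefore has a minimum size but no measured size: the limit of < 100 nM in this assay, at which 1 of the 4 values shown sits.

Going by these compounds, whether the result depends on the nitrile itself or on the loss of phenyl stays open, and an amine, a carboxylic acid or a longer chain ending in a nitrile on the same saturated chain carbon would help separate the two.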